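Extending a Benzyl Substituent on a Cytotoxic Amidine Core

This account rests on a few compounds, and the source may have more. Where it says the series, first, only, none or still open, it means among the compounds named here.

Of the compounds shown here, two have been tested so far in a functional assay on HT-1080 cells (Homo sapiens) for cytotoxicity, read by MTT assay, with a stated time of 72 h; a lower number here means a stronger inhibitor, a higher number a weaker inhibitor. Compound 1 `COc1ccc(Cn2nc(-c3ccccc3)c3cc(C(=N)Nc4ccccc4)ncc32)cc1` gives 4700 nM, while compound 2 `CN1CCN(c2ccc(NC(=N)c3cc4c(-c5ccccc5)nn(C)c4cn3)cc2)CC1` gives 1400 nM. Compound 2 therefore stands lowest of the two numbers, and its gap to compound 1 lies beyond the usual scatter of this assay.

Compound 3 `COc1ccc(Cn2nc(-c3ccccc3)c3cc(C(=N)Nc4ccc(N5CCN(C)CC5)cc4)ncc32)cc1` has not yet been measured. It differs from compound 2 by a single change: 4-methoxyphenyl in place of hydrogen on a saturated chain carbon bound to an aromatic nitrogen. Read one bond further out, this is methyl giving way to 4-methoxybenzyl. Compound 1 already carries this same 4-methoxybenzyl group on the shared core, though with a different amidine partner, and in this assay compound 1 gives 4700 nM.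

Among the measured compounds shown here, no directly comparable step is known, so the change from compound 2 to compound 3 is expected to be small, with a slight lean toward a weaker result, as a 1.6-fold higher number from compound 2 to compound 3 (0.20 log units; within the scatter). Compound 3 is estimated at 2200 nM, within a range from 700 nM to 7000 nM.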

Compound 3, half-maximal inhibitory concentration: 1090 nM
Beside the measured number, compound 3's estimate is 2.0-fold (0.30 log units) above it; low and high end bracket the measured number.
By their numbers in this assay, from the lowest: compounds 3 and 2 (each within the scatter of the next); then compound 1.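

In this assay, the step from methyl to 4-methoxybenzyl gives a 1.3-fold lower number from compound 2 to compound 3 (0.11 log units; within the scatter), so with the 4-methylpiperazin-1-yl group in place, this position holds the larger group with no change beyond the scatter. With 4-methoxybenzyl held constant, adding 4-methylpiperazin-1-yl in place of hydrogen on an aromatic carbon gives a 4.3-fold lower number from compound 1 to compound 3 (0.63 log units; beyond the scatter), a modest step that shows this second site of change does affect the reading. No supporting data explain either result.

A compound pairing methyl with the amidine partner of compound 1 would show whether the effect of 4-methylpiperazin-1-yl depends on the group at the first position. On these data alone, it also remains open how this position would respond to an amine, a carboxylic acid or a longer chain.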